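Swapping one hydroxy for hydrogen on compound 2's chain

The source may report more compounds than this note shows. Statements on the series, on what has been measured and on what is new or still open speak of the compounds shown alone.

Measured in an ADME assay on microsomes from liver (Rattus norvegicus) for metabolic stability, read by mass spectrometry, with a stated time of 10 min, tested at 0.5 uM (on this read-out higher numbers stand for a more stable compound and lower numbers for a less stable compound), compound 2 (`CNc1cc(Nc2cc(C)cc(C)c2)nn2c(C(=O)NCC(C)(CO)CO)cnc12`) gives 16% and stands level with compound 3 (`CNc1cc(Nc2cccc(-c3ccccc3)c2)nn2c(C(N)=O)cnc12`), which gives 16% so that the two lie within the usual scatter of each other. Compound 1 (`CNc1cc(Nc2c(F)c(F)cc(F)c2F)nn2c(C(=O)NC[C@](C)(O)CO)cnc12`) gives 40% and lies beyond that scatter, higher than both. Among the compounds with values here, these three differ in more than one place, so no measured pair isolates a single change.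

The next compound is compound 4 (`CNc1cc(Nc2cc(C)cc(C)c2)nn2c(C(=O)NCC(C)(C)CO)cnc12`). The change from compound 2 (hydrogen in place of hydroxy on a saturated chain carbon, three bonds along the chain from an amide-type nitrogen and an oxygen on a saturated carbon) puts hydrogen in place of hydroxy on a saturated chain carbon, three bonds along the chain from an amide-type nitrogen and an oxygen on a saturated carbon. It reads as 2,2-bis(hydroxymethyl)propyl to 2-(hydroxymethyl)-2-methylpropyl.

The data hold no direct measure of this swap. Compound 3, which lacks this chain altogether, still stands at 16% and so only a small step is expected, although compound 3 also differs elsewhere. In this assay the expected step is a number 2 percentage points lower from compound 2 to compound 4 (within the scatter) and it is expected to stay within the scatter, leaning slightly downward. Compound 4 is estimated at 14% (expected range 5% to 28%).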

Compound 4, percent of the compound remaining: 4%
Estimate against measurement, compound 4: 10 percentage points above; measured number below the stated range.
By their numbers in this assay, from the lowest: compound 4; then compounds 2 and 3 (each within the scatter of the next); then compound 1.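

Hydrogen in place of hydroxy on this saturated chain carbon gives, in this assay, a number 12 percentage points lower from compound 2 to compound 4 (beyond the scatter) and so provides the first reading of a single change in this series. The earlier compounds shown here differed in more than one place and could not show whether this chain position affected the read-out, whereas this pair, which differs only in going from 2,2-bis(hydroxymethyl)propyl to 2-(hydroxymethyl)-2-methylpropyl, shows that losing one hydroxy here is enough to move the number by more than the usual scatter. Nothing measured here accounts for the step, so its origin remains unexplained.

The compounds shown leave open whether removing the remaining hydroxy would lower the number further and whether the same swap would give a step of like size with the different substituent pattern of compound 1. Also open, going by these compounds, is how an amine, a methoxy group or a carboxylic acid would read at this place on the chain, as this pair compares only hydroxy with hydrogen.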